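From 3-fluorophenyl to 4-methylphenyl on the nitrogen

This account rests on a few compounds, and the source may have more. Where it says the series, first, only, none or still open, it means among the compounds named here.

In a functional assay on MCF7 cells (Homo sapiens) for inhibition, read by trypan blue exclusion, with a stated time of 3 days (on this read-out higher numbers stand for weaker inhibition and lower numbers for stronger inhibition), compound 3 `COc1cc(C(=O)c2cn(-c3cccc(F)c3)cc2-c2ccccc2)cc(OC)c1OC`, with 3-fluorophenyl on an aromatic nitrogen, gives 350 nM as its number. Compound 1 `COc1cc(C(=O)c2cn(-c3ccccc3)cc2-c2ccc(C)cc2)cc(OC)c1OC` gives 280 nM and so sits within the scatter of compound 3. Compound 2 `COc1cc(C(=O)c2cn(-c3ccccc3F)cc2-c2ccccc2)cc(OC)c1OC`, with 2-fluorophenyl there, gives 85 nM as a clearly lower number. Among the compounds with values here, the one measured step at this place is a 4.1-fold higher number from compound 2 to compound 3 (0.61 log units; beyond the scatter) and shows that a change there can move the number. Compound 4 `COc1cc(C(=O)c2cn(-c3ccc(C)cc3)cc2-c2ccccc2)cc(OC)c1OC` carries 4-methylphenyl in place of 3-fluorophenyl on an aromatic nitrogen. Within the data shown here, no measured step covers this swap, so no clear direction is expected in this assay and the expected 1.2-fold lower number from compound 3 to compound 4 (0.07 log units; within the scatter) would stay within the scatter. For compound 4 the estimated value is 300 nM with an expected range (110 nM to 800 nM).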

Compound 4, half-maximal inhibitory concentration: 30 nM
Compound 4: middle estimate off by 10-fold (1.00 log units), on the high side, and the stated range ends above it.
By their numbers in this assay, from the lowest: compound 4; then compound 2; then compounds 1 and 3 (each within the scatter of the next).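

Within the data shown here, putting 4-methylphenyl in place of 3-fluorophenyl on the aromatic nitrogen gives a 12-fold lower number from compound 3 to compound 4 (1.07 log units; beyond the scatter) in this assay, a larger move at this place than the one step seen before. Among these compounds, the new group also goes past 2-fluorophenyl, which held the lowest number so far, with a 2.8-fold lower number from compound 2 to compound 4 (0.45 log units; beyond the scatter). No measurement at hand explains this gain.

Still open, going by these compounds, is whether the methyl group itself carries the gain, since 4-methylphenyl is the only methyl-bearing ring on this nitrogen here. On these data alone, how an ethyl group, a methoxy group or an amine would do in place of that methyl also remains open.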